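Cytotoxicity of a nitro-for-methoxy swap in benzimidazoles

The compounds below may be only part of what the source reports. "The series", "measured", "known", "first", "only" and "open" are said of these compounds alone.

Compound 1 `COc1ccc(-c2nc3cc(Cl)c(Cl)cc3[nH]2)cc1`: 2500 nM
Compound 2 `CC(=O)Nc1ccc(-c2nc3cc(C(F)(F)F)ccc3n2C)cc1`: 46000 nM
Compound 3 `COc1ccc(-c2nc3cc(Cl)c(Cl)cc3[nH]2)c([N+](=O)[O-])c1`: 28000 nM

These values come from an ADME assay on MDBK cells (Bos taurus) for cytotoxicity, read by MTT assay, with a stated time of 96 h; a lower number here means that less compound is tolerated, a higher number that more compound is tolerated. Compound 1 gives the lowest number of the three; the nearest is compound 3 with 28000 nM, and the furthest is compound 2 with 46000 nM. Compound 4 `O=[N+]([O-])c1ccc(-c2nc3cc(Cl)c(Cl)cc3[nH]2)cc1` is not yet measured. It differs from compound 1 in one place: nitro in place of methoxy on an aromatic carbon. Among the measured compounds shown here, only one measured step bears on this: an 11-fold higher number from compound 1 to compound 3 (1.05 log units; beyond the scatter), where a nitro group entered the same ring. That step was large and pointed toward a higher number, though there the methoxy stayed in place. For compound 4 an upward step in this assay is therefore expected, a 3.2-fold higher number from compound 1 to compound 4 (0.51 log units; beyond the scatter). Compound 4 is estimated at 8000 nM, within 2500 nM to 30000 nM.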

Compound 4, half-maximal cytotoxic concentration: 56000 nM
Beside the measured number, compound 4's estimate is 7.0-fold (0.85 log units) below it; measured number above the stated range.
By their numbers in this assay, from the lowest: compound 1; then compounds 3, 2 and 4 (each within the scatter of the next).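

On the aromatic carbon para to a large group, nitro in place of methoxy gives a 22-fold higher number from compound 1 to compound 4 (1.35 log units; beyond the scatter) in this assay. A large upward step therefore appears with nitro even when the methoxy is gone, whereas the earlier nitro step kept that group in place. Nothing measured here explains why the number rises. From the compounds shown here alone, it remains open how much of the step comes from losing methoxy and how much from gaining nitro. Going by these compounds, it is also open whether an amine or a carboxylic acid on this carbon would move the number the same way.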